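A Bromophenyl Urea Tested Against Lung Cancer Cells

This account rests on a few compounds, and the source may have more. Where it says the series, first, only, none or still open, it means among the compounds named here.

Compound 1 `COc1cc(NC(C)CCCNC(=O)NNC(=O)Nc2ccc(O)cc2)c2ncccc2c1` — in a functional assay on NCI-H460 cells (Homo sapiens) for inhibition, read by MTT assay, with a stated time of 72 h (on this read-out lower numbers stand for stronger inhibition and higher numbers for weaker inhibition), compound 1 reaches only the assay limit of > 100000 nM.
Compound 2 `COc1cc(NC(C)CCCNC(=O)Nc2cccc(F)c2)c2ncccc2c1` — compound 2 gives 24000 nM.
Compound 3 `COc1cc(NC(C)CCCNC(=O)Nc2cccc(O)c2)c2ncccc2c1` — compound 3 gives 25000 nM.

Compound 3 stands at the higher of the two numbers actually reported, yet compound 2 sits so close that the two cannot be told apart, as the step of a 1.0-fold higher number from compound 2 to compound 3 (0.02 log units; within the scatter) lies within the scatter. Compound 1 is known only as a limit (the limit of > 100000 nM in this assay, at which 1 of the 3 values shown sits), so the step of an at least 4.0-fold lower number from compound 1 to compound 3 (0.60 log units; beyond the scatter) is a lower bound on how far compound 3 improves on it.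

Compound 4 `COc1cc(NC(C)CCCNC(=O)Nc2ccc(Br)cc2)c2ncccc2c1` differs from compound 3 in one place: 4-bromophenyl in place of 3-hydroxyphenyl on an amide-type nitrogen. Of the measured steps, only a 1.0-fold higher number from compound 2 to compound 3 (0.02 log units; within the scatter) changes a group on the phenyl ring while keeping the shared core, and it was flat. The steps of an at least 4.1-fold lower number from compound 1 to compound 2 (0.61 log units; beyond the scatter) and an at least 4.0-fold lower number from compound 1 to compound 3 (0.60 log units; beyond the scatter) show that a simple arylurea gives a real number rather than a limit. Within the data shown here, no measured step places a bromine on the ring, so the expectation for compound 4 rests on the flat step alone: the estimated change a 1.3-fold lower number from compound 3 to compound 4 (0.10 log units; within the scatter) is none beyond the scatter. Compound 4 is therefore expected at about 20000 nM, within 7000 nM to 60000 nM.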

Compound 4, half-maximal inhibitory concentration: 30000 nM
Compound 4: middle estimate off by 1.5-fold (0.18 log units), on the low side, and the stated range covers the measured number.
By their numbers in this assay, from the lowest: compounds 2, 3 and 4 (each within the scatter of the next). At a limit, above all of these: compound 1.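

The change from 3-hydroxyphenyl to 4-bromophenyl on the amide-type nitrogen swaps a group with 1 hydrogen-bond donor and 1 hydrogen-bond acceptor for one with 0 hydrogen-bond donors and 0 hydrogen-bond acceptors, and moves the ring substituent's numbered position, yet in this assay it gives a 1.2-fold higher number from compound 3 to compound 4 (0.08 log units; within the scatter), while the change from 3-fluorophenyl gives a 1.3-fold higher number from compound 2 to compound 4 (0.10 log units; within the scatter). Among these compounds, the earlier flat step covered only one ring position and two small substituents, so these results extend the flat picture to a bromine at a different ring position, with compounds 2, 3 and 4 all within the scatter of one another. The step of an at least 3.3-fold lower number from compound 1 to compound 4 (0.52 log units; beyond the scatter) adds a third simple arylurea that gives a real number and is a bound rather than an exact size, since compound 1 has only a limit: the limit of > 100000 nM in this assay, at which 1 of the 4 values shown sits.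

The compounds shown leave open whether an amine or a carboxylic acid on this phenyl ring, or a longer chain in the shared core, would shift the number beyond the scatter. Since compound 4 differs from compounds 2 and 3 in both the substituent and its ring position, the effects of those two changes also remain unseparated.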